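Ring Size on the Amide Nitrogen: Cyclopentyl to Cyclohexyl

A few compounds are considered here, and "the series" means these few. Any claim that something is new, unique, unknown or untested is made for them only; others in the source may bear on it.

Compound 1 `Cc1ccc(C#Cc2ccc3c(n2)CCN(C2CCCC2)C3=O)cc1` in an assay on HEK293 cells for displacement of a labelled ligand from metabotropic glutamate receptor 5 (Homo sapiens), with a stated time of 2 h (on this read-out lower numbers stand for stronger inhibition and higher numbers for weaker inhibition), gives only a limit of the assay, > 32000 nM.
Compound 2 `O=C1c2ccc(C#Cc3cccc(Cl)c3)nc2CCN1C1CCCC1` in this assay gives 5230 nM.
Compound 3 `O=C1c2ccc(C#Cc3cccs3)nc2CCN1C1CCCC1` in this assay gives 2840 nM.

Compound 2 stands highest of the two numbers shown; its nearest neighbour is compound 3, with a 1.8-fold lower number from compound 2 to compound 3 (0.27 log units; within the scatter). Compound 4 `O=C1c2ccc(C#Cc3cccc(Cl)c3)nc2CCN1C1CCCCC1` is not yet measured. It differs from compound 2 by cyclohexyl in place of cyclopentyl on an amide-type nitrogen in a ring. Among the measured compounds shown here, none of the measured steps touches this position: an at least 6.1-fold lower number from compound 1 to compound 2 (0.78 log units; beyond the scatter) and an at least 11-fold lower number from compound 1 to compound 3 (1.05 log units; beyond the scatter) concern the group on the triple-bonded carbon, and the limit of > 32000 nM in this assay, at which 1 of the 3 values shown sits, marks compound 1 as a limit. For the measured compounds named here, with no step bearing on the amide-type nitrogen, the expected change is a 1.0-fold lower number from compound 2 to compound 4 (0.02 log units; within the scatter), none beyond the scatter. Compound 4 is therefore estimated at 5000 nM, between 1500 nM and 16000 nM.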

Compound 4, inhibition constant: 12000 nM
The estimate for compound 4 lay 2.4-fold (0.38 log units) below the measured number; the measured number falls inside the stated range.
By their numbers in this assay, from the lowest: compounds 3 and 2 (each within the scatter of the next); then compound 4. At a limit, above all of these: compound 1.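

In this assay the group on the amide-type nitrogen turns out to matter: cyclohexyl in place of cyclopentyl gives a 2.3-fold higher number from compound 2 to compound 4 (0.36 log units; beyond the scatter), so the six-membered ring reads weaker than the five-membered one on the shared core. The earlier compounds shown here all carry cyclopentyl there and showed nothing of this position. The data give no reason for this step.

From the compounds shown here alone, whether the step holds with thiophen-2-yl or 4-methylphenyl on the triple-bonded carbon stays open. So does how cyclobutyl, an open chain such as isopropyl, or a ring carrying an amine would read on that nitrogen.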